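The source may hold more compounds than are shown below. What is called first, only, known or untested is meant among the compounds shown, and "the series" means these compounds.

Four compounds here share a core and differ in their side groups: compound 1 `CC(C)CCn1nc(-c2cccs2)c(O)c(C2=NS(=O)(=O)c3cc(S(=O)(=O)N(C)C)ccc3N2)c1=O`, compound 2 `CC(C)CCn1nc(C2CCCCC2)c(O)c(C2=NS(=O)(=O)c3cc(NS(C)(=O)=O)ccc3N2)c1=O`, compound 3 `CC(C)CCn1nc(C2CCCC2)c(O)c(C2=NS(=O)(=O)c3cc(NS(C)(=O)=O)ccc3N2)c1=O` and the still unmeasured compound 4 `CC(C)CCn1nc(CC2=CCCC2)c(O)c(C2=NS(=O)(=O)c3cc(NS(C)(=O)=O)ccc3N2)c1=O`. In an ADME assay on Huh-7 cells (Homo sapiens) for cytotoxicity, with a stated time of 72 h (a lower number here means that less compound is tolerated, a higher number that more compound is tolerated), compound 1 has the entry "not determined" (no result reported). Compound 2 gives > 1000 nM, which is a limit of the assay and not a number. Compound 3 gives > 1000 nM, again only a limit. Compound 3 therefore stands at the limit of > 1000 nM in this assay, at which 2 of the 3 values shown sit, and its true value is not known.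

The change to compound 4 is (cyclopent-1-en-1-yl)methyl in place of cyclopentyl on an aromatic carbon, with (cyclopent-1-en-1-yl)methyl in place of cyclopentyl on an aromatic carbon. Going by the values given here, the one measured step at this carbon, a step that the two limits leave unreadable from compound 2 to compound 3, has no size that can be carried over, so no shift beyond the usual scatter is expected in this assay. The expected step is a step that the limit leaves unreadable from compound 3 to compound 4. For compound 4 the estimated value is 5000 nM, with an expected range of 1000 nM to 30000 nM.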

Compound 4, half-maximal cytotoxic concentration: > 33000 nM
Compound 4 was reported as a limit (the forecaster's own chance of this, stated with the estimate: 75%); middle value at least 6.6-fold (0.81 log units) away from the limit.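

In this assay compound 4 gives > 33000 nM, which is a limit of the assay. Compound 2 and compound 3 are also reported only as limits, so no step among these three can be read. The compounds shown leave open whether changing this side group alters cytotoxicity at all.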